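The source may report more compounds than this note shows. Statements on the series, on what has been measured and on what is new or still open speak of the compounds shown alone.

Measured compounds:

Compound 1 `COc1ccc2ccc(=O)oc2c1C1=NNC(c2ccc(SC)cc2)C1` gives 10 nM in a functional assay on HepG2 cells (Homo sapiens) for cytotoxicity, read by MTT assay, with a stated time of 72 h; on this read-out lower numbers stand for stronger inhibition and higher numbers for weaker inhibition.
Compound 2 `COc1ccc2ccc(=O)oc2c1C1=NN(c2ccccc2)C(c2ccc(SC)cc2)C1` gives 78 nM in this assay.
Compound 3 `COc1ccc2ccc(=O)oc2c1C1=NN(c2ccccc2)C(c2ccc(C(F)(F)F)cc2)C1` gives 38 nM in this assay.

Compound 2 and compound 3 share a core and differ only by trifluoromethyl in place of methylsulfanyl on an aromatic carbon; that change gave a 2.1-fold lower number from compound 2 to compound 3 (0.31 log units; beyond the scatter). Compound 1 differs from compound 2 by hydrogen in place of phenyl on an amine nitrogen in a ring, and that step was a 7.8-fold lower number from compound 2 to compound 1 (0.89 log units; beyond the scatter). Compound 4 `COc1ccc2ccc(=O)oc2c1C1=NNC(c2ccc(C(F)(F)F)cc2)C1` has not yet been measured. It differs from compound 3 by hydrogen in place of phenyl on an amine nitrogen in a ring, the same kind of change as that from compound 2 to compound 1, though here the amine nitrogen sits next to the ring atom that bears a 4-(trifluoromethyl)phenyl group rather than a 4-(methylsulfanyl)phenyl group. Within the data shown here, compound 4 is therefore expected to give a lower number than compound 3, a step of about a 6.3-fold lower number from compound 3 to compound 4 (0.80 log units; beyond the scatter), resting on the single earlier example, compound 1 against compound 2 with a 7.8-fold lower number from compound 2 to compound 1 (0.89 log units; beyond the scatter). Compound 4 is estimated at 6 nM, between 2 nM and 20 nM.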

Compound 4, half-maximal inhibitory concentration: 13 nM
For compound 4 the middle estimate is 2.2-fold (0.34 log units) below the measured one; low and high end bracket the measured number.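

In this assay, hydrogen in place of phenyl on the ring nitrogen again lowered the number, with a 2.9-fold lower number from compound 3 to compound 4 (0.47 log units; beyond the scatter), so the direction carried over from one core to the other, but the size did not: the same change on two cores in this assay, a 7.8-fold lower number (0.89 log units; beyond the scatter) from compound 2 to compound 1 and a 2.9-fold lower number (0.47 log units; beyond the scatter) from compound 3 to compound 4, 2.7-fold (0.43 log units) apart, beyond the scatter of two such steps
Trifluoromethyl in place of methylsulfanyl gave a 1.3-fold higher number from compound 1 to compound 4 (0.11 log units; within the scatter) where the ring nitrogen bears hydrogen, so the step seen with phenyl there did not carry over: the same change on two cores in this assay, a 2.1-fold lower number (0.31 log units; beyond the scatter) from compound 2 to compound 3 and a 1.3-fold higher number (0.11 log units; within the scatter) from compound 1 to compound 4, 2.7-fold (0.43 log units) apart, beyond the scatter of two such steps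
Among these compounds, with only one pair of steps for each change, this shows that the two changes do not simply add in these four compounds, but it does not show why or whether this extends to other cores.

The compounds shown leave open how a methyl or an acetyl on the ring nitrogen would compare with hydrogen and phenyl. They also leave open what an amine or a carboxylic acid in place of trifluoromethyl would give.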